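A few compounds are considered here, and "the series" means these few. Any claim that something is new, unique, unknown or untested is made for them only; others in the source may bear on it.

Measured so far:
compound 1, `O=C(O)c1cccc(C2CC2c2ccc(OCc3c(-c4c(Cl)cccc4Cl)noc3C3CC3)cc2Cl)c1`, in an assay on HEK293 cells for agonist activity at Bile acid receptor (Homo sapiens) (a lower number here means that less compound is needed, a higher number that more compound is needed for the effect), gives 34 nM
compound 2, `O=C(O)c1cccc([C@H]2C[C@](OCCO)(c3ccc(OCc4c(-c5c(Cl)cccc5Cl)noc4C4CC4)cc3Cl)C2)c1`, in this assay gives 377 nM

Compound 1 stands at the lower of the two numbers in this assay; compound 2 gives a higher number, and that gap lies beyond the scatter. Compound 3, `O=C(O)c1ccc(C2CC2c2ccc(OCc3c(-c4c(Cl)cccc4Cl)noc3C3CC3)cc2Cl)cn1`, is not yet measured. It differs from compound 1 in one place: 6-carboxypyridin-3-yl in place of 3-carboxyphenyl on a saturated ring carbon. For the measured compounds named here, no measured pair shows this change, so its size is unknown. A small step toward a higher number, near the edge of the scatter, is expected from compound 1 to compound 3, a 1.8-fold higher number from compound 1 to compound 3 (0.25 log units; within the scatter). Compound 3 is expected to give 60 nM, within a range of 20 nM to 200 nM.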

Compound 3, half-maximal effective concentration: 57 nM
Compound 3: middle estimate off by 1.1-fold (0.02 log units), on the high side; measured number inside the range.
By their numbers in this assay, from the lowest: compounds 1 and 3 (each within the scatter of the next); then compound 2.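

In this assay, 6-carboxypyridin-3-yl in place of 3-carboxyphenyl on a saturated ring carbon gives a 1.7-fold higher number from compound 1 to compound 3 (0.22 log units; within the scatter), so compound 1 and compound 3 cannot be told apart. This first single-place pair shows that the three-membered ring carbon can carry a six-membered aromatic ring with a hetero atom, and an added hydrogen-bond acceptor, without a step beyond the scatter. Nothing available here explains this result.

Still open, on these data alone, is whether a tetrazole or a primary amide could stand in place of the carboxylic acid on either ring. Also open, as far as these compounds go, is how a pyrimidine ring would read at this place.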